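Methoxy in Place of Chloro: Expected Clearance of Compound 3

This account rests on a few compounds, and the source may have more. Where it says the series, first, only, none or still open, it means among the compounds named here.

Compound 1, `FC(F)Oc1ccccc1C1Cc2nccn2C1`: 22 mL.min-1.g-1
Compound 2, `Clc1ccccc1C1Cc2nccn2C1`: 18 mL.min-1.g-1

In an in vitro ADME assay on microsomes from liver (Homo sapiens) for metabolic stability (a lower number here means slower removal, a higher number faster removal of the compound), compound 2 stands at the lowest of the two numbers; its nearest neighbour is compound 1, and the step of a 1.2-fold lower number from compound 1 to compound 2 (0.09 log units; within the scatter) lies within the scatter. Compound 3, `COc1ccccc1C1Cc2nccn2C1`, has not yet been measured. It differs from compound 2 by methoxy in place of chloro on an aromatic carbon. Within the data shown here, the only measured step that bears on this site is the one from compound 1 to compound 2, where chloro replaced difluoromethoxy on the same aromatic carbon, and that step was within the scatter. Among the measured compounds shown here, no measured pair shows methoxy at this position. On that basis the account expects the step of a 1.2-fold higher number from compound 2 to compound 3 (0.09 log units; within the scatter) to be small, with no clear direction beyond the scatter. The estimate for compound 3 in this assay is therefore 22 mL.min-1.g-1, with a range from 11 mL.min-1.g-1 to 44 mL.min-1.g-1.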

Compound 3, intrinsic clearance in microsomes: 37 mL.min-1.g-1
The estimate for compound 3 lay 1.7-fold (0.23 log units) below the measured number, and the stated range covers the measured number.
By their numbers in this assay, from the lowest: compounds 2, 1 and 3 (each within the scatter of the next, the first and the last beyond it).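

In this assay, among these compounds, methoxy in place of chloro on the aromatic carbon gives a 2.1-fold higher number from compound 2 to compound 3 (0.31 log units; beyond the scatter) and so is the only modest change at this position that stands beyond the scatter. Methyl in place of difluoromethyl on the oxygen gives a 1.7-fold higher number from compound 1 to compound 3 (0.23 log units; within the scatter) and stays within the scatter, so compound 1 cannot be told apart from compound 3, just as it could not be told apart from compound 2, and only compound 2 and compound 3 are separated. Nothing measured here bears on why this change at this position shifts the number.

The compounds shown leave open how an amine, a nitrile or a longer chain such as ethoxy would read at this carbon in this assay and whether the step from chloro to methoxy would hold on another core.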